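Amine nitrogen substituents: compound 2 to compound 3

The source may report more compounds than this note shows. Statements on the series, on what has been measured and on what is new or still open speak of the compounds shown alone.

Values in a functional assay on MT4 cells (Homo sapiens); a lower number here means that less compound is tolerated, a higher number that more compound is tolerated:
- compound 1 `Cc1cn([C@@H]2O[C@H](CO[Si](C)(C)C(C)(C)C)[C@@]3(OS(=O)(=O)C=C3NCC(N)=O)[C@H]2O[Si](C)(C)C(C)(C)C)c(=O)n(C)c1=O`: 14900 nM
- compound 2 `COC(=O)CNC1=CS(=O)(=O)O[C@@]12[C@@H](CO[Si](C)(C)C(C)(C)C)O[C@@H](n1cc(C)c(=O)n(C)c1=O)[C@@H]2O[Si](C)(C)C(C)(C)C`: 105000 nM

Compound 2 holds the higher of the two numbers in this assay. Compound 3 `Cc1cn([C@@H]2O[C@H](CO[Si](C)(C)C(C)(C)C)[C@@]3(OS(=O)(=O)C=C3NC(=O)c3ccccc3)[C@H]2O[Si](C)(C)C(C)(C)C)c(=O)n(C)c1=O` has not yet been measured. It differs from compound 2 by benzoyl in place of (methoxycarbonyl)methyl on an amine nitrogen. Among the compounds with values here, the only measured step bearing on this, a 7.0-fold higher number from compound 1 to compound 2 (0.85 log units; beyond the scatter), is modest and alters the same substituent at its far end only. It offers a rough scale, and the whole group changes here. With compound 2 at the top of just two values, a step of similar size downward is expected. The estimated step is a 3.0-fold lower number from compound 2 to compound 3 (0.48 log units; beyond the scatter). Compound 3 is estimated at 35000 nM, with an expected range of 9000 nM to 130000 nM.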

Compound 3, half-maximal cytotoxic concentration: 4900 nM
Beside the measured number, compound 3's estimate is 7.1-fold (0.85 log units) above it; the measured number lies below the stated range.
By their numbers in this assay, from the lowest: compound 3; then compound 1; then compound 2.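

In this assay, exchanging the whole amine substituent gives a larger step (a 21-fold lower number from compound 2 to compound 3 (1.33 log units; beyond the scatter)) than changing only its far end (a 7.0-fold higher number from compound 1 to compound 2 (0.85 log units; beyond the scatter)). Benzoyl also gives the lowest number of the three, including against the carbamoylmethyl group (a 3.0-fold lower number from compound 1 to compound 3 (0.48 log units; beyond the scatter)), so the number at this amine nitrogen does not simply track the ester-to-amide change at the chain end. No measurement available here accounts for these steps. Open, as far as these compounds go, is whether the benzoyl result follows the carbonyl on the nitrogen or the aromatic ring. Acetyl and benzyl on the same nitrogen would separate the two.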